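Methoxy removal on the cinnamamide aryl group

A few compounds are considered here, and "the series" means these few. Any claim that something is new, unique, unknown or untested is made for them only; others in the source may bear on it.

Compound 2 `COc1cc(C(=O)c2cc(OC)c(OC)c(OC)c2)cc(NC(=O)/C=C/c2cc(OC)c(OC)c(OC)c2)c1OC` gives 4800 nM in a functional assay on PC-3 cells (Homo sapiens) for cytotoxicity, read by MTT assay, with a stated time of 72 h; on this read-out higher numbers stand for weaker inhibition and lower numbers for stronger inhibition. Compound 1 `COc1ccc(C(=O)c2cc(OC)c(OC)c(OC)c2)cc1NC(=O)/C=C/c1ccc(OC)c(OC)c1` gives 7500 nM in this assay, and the two values lie within the scatter of each other, so no ranking between them is drawn. Compound 3 `COc1ccc(/C=C/C(=O)Nc2cc(C(=O)c3cc(OC)c(OC)c(OC)c3)cc(OC)c2OC)cc1OC` differs from compound 2 by hydrogen in place of methoxy on an aromatic carbon. Among the measured compounds shown here, no measured pair shows this change, so its effect cannot be read from steps already seen; the step of a 1.1-fold higher number from compound 2 to compound 3 (0.06 log units; within the scatter) is expected to stay within the scatter, in no particular direction. Compound 3 is therefore estimated at 5500 nM, with a range from 2500 nM to 12000 nM.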

Compound 3, half-maximal inhibitory concentration: 5400 nM
For compound 3 the middle estimate is 1.0-fold (0.01 log units) above the measured one, and the stated range covers the measured number.
By their numbers in this assay, from the lowest: compounds 2, 3 and 1 (each within the scatter of the next).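

In this assay, the change from 3,4,5-trimethoxyphenyl to 3,4-dimethoxyphenyl gives a 1.1-fold higher number from compound 2 to compound 3 (0.05 log units; within the scatter), so this methoxy can be replaced by hydrogen with no readable effect on the value. The second single change, methoxy in place of hydrogen on an aromatic carbon of the shared core, gives a 1.4-fold lower number from compound 1 to compound 3 (0.14 log units; within the scatter), which is also no readable effect. No available measurement accounts for how closely these values sit.

Going by these compounds, whether an amine, a hydroxyl or a longer alkoxy chain at the cinnamamide position would move the value beyond the scatter remains open. On these data alone, the effect of removing the remaining methoxy groups from the 3,4-dimethoxyphenyl ring also remains open.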